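Sulfonylurea to sulfonylthiourea at the sulfonamide nitrogen

The source may report more compounds than this note shows. Statements on the series, on what has been measured and on what is new or still open speak of the compounds shown alone.

Measured so far:
compound 1 `Cc1cc(C(=O)O)nn1-c1ccc(S(=O)(=O)NC(=S)NC2CCCCC2)cc1`: 1%
compound 2 `CCNC(=O)NS(=O)(=O)c1ccc(-n2nc(C)cc2C)cc1`: < 1%
compound 3 `Cc1cc(C(=O)O)nn1-c1ccc(S(=O)(=O)NC(=O)NCc2ccccc2)cc1`: 0%

The read-out throughout is a functional assay on the whole organism (blood, strain albino) with Mus musculus as the target, with stated times of 6 days and 4 h, at a dose of 0.4 mmol/kg by the oral route; a higher number here means more inhibition at the dose given (going by the name of the read-out), a lower number less inhibition. In this assay compound 1 gives 1% and compound 3 gives 0%; both lie within the usual scatter of no effect. For compound 2 the value < 1% is a limit of the assay and not a number, as noted in the limit of < 1% in this assay, at which 1 of the 3 values shown sits. Compound 2 therefore stands at the floor of the numbers shown, and neither compound 1 nor compound 3 can be told apart from it on these values.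

Compound 4 `CCCNC(=S)NS(=O)(=O)c1ccc(-n2nc(C)cc2C)cc1` has not yet been measured. It differs from compound 2 in one place: a group of 6 heavy atoms (4 carbon, 1 nitrogen, 1 sulfur; no ring) in place of a group of 5 heavy atoms (3 carbon, 1 nitrogen, 1 oxygen; no ring), on a sulfonamide nitrogen.

For the measured compounds named here, no step between measured compounds exists here that rises above the scatter, so the numbers give no direction for this change. The expected step of a number at least 1 percentage points higher from compound 2 to compound 4 (that floor lies within the scatter) is none beyond the scatter. Compound 4 is expected to give about 2% in this assay, with a range from 0% to 10%.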

Compound 4, a percentage reported as inhibition, in the whole organism at one dose (the size of the read-out at that dose, not a potency): < 1%
Compound 4 gave a limit, no number; the forecaster's own chance of this, stated with the estimate: 35%; middle value at least 1 percentage points away from the limit.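

In this assay compound 4 gives < 1%, a limit and not a number. Compound 2 and compound 4 both sit at a limit, so no step between them can be read: the limit of < 1% in this assay, at which 2 of the 4 values shown sit.

The compounds shown leave open whether this change on the sulfonamide nitrogen has any effect on inhibition in this assay.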